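The compounds below may be only part of what the source reports. "The series", "measured", "known", "first", "only" and "open" are said of these compounds alone.

Compound 2 `CCNc1cc(-c2ccc(NC(=O)Nc3cccc(Cl)c3)cc2C(F)(F)F)ccn1` stands highest of the three numbers measured in an assay on isolated protein for inhibition of serine/threonine-protein kinase PLK1 (Homo sapiens), read by radiometric assay and 33P incorporation, with a stated time of 40 min, tested at 20 uM, in the presence of a further agent that is not named here; a higher number here means more inhibition at the concentration tested (going by the name of the read-out), a lower number less inhibition: compound 2 gives 94.9%. Its nearest neighbour is compound 3 `CCNc1cc(-c2ccc(NC(=O)Nc3cccc(Cl)c3)cc2F)ccn1`, which in this assay gives 72.7%, and the furthest is compound 1 `CCNc1cc(-c2ccc(NC(=O)Nc3ccc(C)cc3)cc2C(F)(F)F)ccn1`, which in this assay gives 42.6%. The two measured steps sit elsewhere in the molecule: a number 52.3 percentage points higher from compound 1 to compound 2 (beyond the scatter), and a number 22.2 percentage points lower from compound 2 to compound 3 (beyond the scatter). Compound 4 `CCCNc1cc(-c2ccc(NC(=O)Nc3cccc(Cl)c3)cc2C(F)(F)F)ccn1` differs from compound 2 by methyl in place of hydrogen on a saturated chain carbon, two bonds along the chain from a nitrogen on an aromatic ring. For the measured compounds named here, neither measured step touches the ethylamino chain, so no measured step bears directly on this change; the measured steps show only that exchanging the group on the amide-type nitrogen or on the aromatic carbon moved the number considerably. With no measured guidance on the chain, a step near the scatter is expected for compound 4, a number 6.9 percentage points lower from compound 2 to compound 4 (within the scatter). The inhibition of compound 4 in this assay is therefore estimated at 88%, within 68% to 98%.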

Compound 4, a percentage reported as inhibition, at one concentration (the size of the read-out at that concentration, not a potency): 63%
Compound 4: middle estimate off by 25 percentage points, on the high side; the whole stated range lies above it.
By their numbers in this assay, from the lowest: compound 1; then compounds 4 and 3 (each within the scatter of the next); then compound 2.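

The ethylamino chain proves to be a place where this read-out responds: in this assay, going from ethylamino to propylamino gives a number 31.9 percentage points lower from compound 2 to compound 4 (beyond the scatter). So one added methyl on a saturated chain carbon, two bonds along the chain from a nitrogen on an aromatic ring, is enough to move the number beyond the scatter, whereas the earlier compounds all carried the same ethylamino chain and showed such movement only for changes elsewhere in the molecule. Nothing available here accounts for this step. 

From the compounds shown here alone, whether a longer chain such as butylamino would lower the number further, or whether a methylamino or a free amino group would raise it, remains open. Going by these compounds, it is also open whether the same chain change would have a similar effect alongside the 4-methylphenyl group of compound 1 or the fluoro group of compound 3.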